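Swapping a Sulfonamide for a Fluorinated Carbinol

The source may report more compounds than this note shows. Statements on the series, on what has been measured and on what is new or still open speak of the compounds shown alone.

compound 1 `CC#C[C@H]1CN(S(=O)(=O)c2ccc(N)nc2)CCN1c1ccc(S(=O)(=O)NC)cn1` — 381 nM
compound 2 `C#CCC(O)(c1ccc(N2CCN(S(=O)(=O)c3ccc(N)nc3)C[C@@H]2C#CC)cc1)C(F)(F)F` — 130 nM

Of the compounds shown here, two have been measured in an assay on cells (Hepatocyte) for inhibition of glucokinase regulatory protein (Mus musculus), with stated times of 20 min and 40 min; on this read-out higher numbers stand for an effect only at larger amounts of compound and lower numbers for an effect already at smaller amounts. Compound 1 gives 381 nM, the higher of the two numbers, and compound 2 gives 130 nM, which lies beyond the scatter below it. For the measured compounds named here, the two compounds differ in more than one place, so no single step connects them. Compound 3 `CC#C[C@H]1CN(S(=O)(=O)c2ccc(N)nc2)CCN1c1ccc(C(O)(C(F)(F)F)C(F)(F)F)cn1` is built from compound 1 by one change: 2,2,2-trifluoro-1-hydroxy-1-(trifluoromethyl)ethyl in place of methylsulfamoyl on an aromatic carbon. Going by the values given here, no measured pair shows this change, so its size can only be guessed. Compound 2, whose value is the lower of the two, offers the only hint of direction. The step from compound 1 to compound 3 is expected to run toward lower numbers, a 2.5-fold lower number from compound 1 to compound 3 (0.40 log units; beyond the scatter), by an amount that may exceed the scatter. Compound 3 is estimated at 150 nM, within 50 nM to 450 nM.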

Compound 3, half-maximal effective concentration: 421 nM
For compound 3 the middle estimate is 2.8-fold (0.45 log units) below the measured one; the range from low to high includes it.
By their numbers in this assay, from the lowest: compound 2; then compounds 1 and 3 (each within the scatter of the next).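

Set on an aromatic carbon two atoms from the ring nitrogen and para to a large group, 2,2,2-trifluoro-1-hydroxy-1-(trifluoromethyl)ethyl in place of methylsulfamoyl gives a 1.1-fold higher number from compound 1 to compound 3 (0.04 log units; within the scatter) in this assay and is the only single change that can be read at this position. The read-out does not tell the two groups apart here, although the entering group has 10 heavy atoms against 5 and holds 1 hydrogen-bond acceptor against 2, while each has 1 hydrogen-bond donor. Nothing measured here offers an explanation of this result. The compounds shown leave open whether a carboxylic acid or an amine on this carbon would also stay within the scatter of compound 1. This single pair also cannot say whether the same exchange would give a similar step on another core.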